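Dropping a Chloro Group on the Shared Core

The compounds below may be only part of what the source reports. "The series", "measured", "known", "first", "only" and "open" are said of these compounds alone.

The measured compounds:
Compound 1 `ClCc1ccc(Cn2cnc3c(Cl)ncnc32)cc1` gives > 100000 nM in a functional assay on MOLT-4 cells (Homo sapiens) for cytotoxicity, read by sulforhodamine B assay, with a stated time of 48 h (a lower number here means that less compound is tolerated, a higher number that more compound is tolerated), a limit of the assay rather than a number.
Compound 2 `ClCc1ccccc1Cn1cnc2c(Cl)nc(Cl)nc21` gives 3540 nM in this assay.

Among the compounds with values here, compound 2 is the only compound with an actual number in this assay; the other value shown is a limit, and compound 1 sits at it. Within the data shown here, compound 2 therefore stands alone, and no step between two measured compounds can be drawn from these data.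

The next compound, compound 3 `ClCc1ccccc1Cn1cnc2c(Cl)ncnc21`, has not yet been measured in this assay. It differs from compound 2 in one place: hydrogen in place of chloro on an aromatic carbon of the shared core.

Among the measured compounds shown here, since no measured step exists, the size of the change is a guess. The expectation is that compound 3 loses potency in this assay beyond the scatter, with a fair chance that only a limit is reported. For compound 3 the expected value in this assay is 30000 nM, with a range from 5000 nM to 100000 nM. That estimate corresponds to an expected step of an 8.5-fold higher number from compound 2 to compound 3 (0.93 log units; beyond the scatter).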

Compound 3, concentration lethal to 50% of the cells: > 100000 nM
Compound 3 ended at the assay's limit (the forecaster's own chance of this, stated with the estimate: 40%); middle value at least 3.3-fold (0.52 log units) away from the limit.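

In this assay, replacing the chloro group on the aromatic carbon between two ring nitrogen atoms with hydrogen gives an at least 28-fold higher number from compound 2 to compound 3 (1.45 log units; beyond the scatter), so the loss of this single atom turns a compound with a measurable lethal concentration into one that the cells tolerate far better. Compound 3 sits at a limit of the assay, not at an actual number: the limit of > 100000 nM in this assay, at which 2 of the 3 values shown sit. Within the data shown here, the step is therefore a minimum, its true size is unknown, and this pair shows only that the chloro group at this position matters strongly for killing these cells when the rest of compound 2 stays the same.

The compounds shown leave open whether chlorine itself is required here or whether another group on this carbon, such as bromo, an amine or a methoxy group, would keep the cytotoxicity. They also leave open whether adding this same chloro group to compound 1, which also sits at a limit, would bring it down to a measurable value.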